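A Hydroxy-Methoxy Swap on a Dichlorophenyl Compound

A few compounds are considered here, and "the series" means these few. Any claim that something is new, unique, unknown or untested is made for them only; others in the source may bear on it.

Measured so far in a functional assay on MCF7 cells (Homo sapiens) for cytotoxicity, read by MTT assay, with a stated time of 72 h; on this read-out lower numbers stand for stronger inhibition and higher numbers for weaker inhibition:
- compound 1 `COc1ccc(/C=C2\CCC/C(=C\c3ccccc3Br)C2=O)cc1OC`: 9500 nM
- compound 2 `COc1ccc(/C=C2\CCC/C(=C\c3cccc(Cl)c3Cl)C2=O)cc1OC`: 14300 nM

Among the measured compounds shown here, only two compounds have been measured, and compound 2 stands within the usual scatter of compound 1, so the two numbers cannot be ranked. The next compound to be tested is compound 3 `COc1cc(/C=C2\CCC/C(=C\c3ccc(OC)c(OC)c3)C2=O)ccc1O`. Its structure differs from that of compound 2 as follows: 4-hydroxy-3-methoxyphenyl in place of 2,3-dichlorophenyl on a double-bonded chain carbon bound to a double-bonded ring carbon. In short, 4-hydroxy-3-methoxyphenyl replaces 2,3-dichlorophenyl on a double-bonded chain carbon bound to a double-bonded ring carbon.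

Just one measured step bears on this place: a 1.5-fold higher number from compound 1 to compound 2 (0.18 log units; within the scatter). That swap of one group for another left the number within the scatter. For the measured compounds named here, it is weak evidence, since no measured compound carries the incoming group. With no sign of a larger effect, the expected step in this assay is a 1.6-fold lower number from compound 2 to compound 3 (0.20 log units; within the scatter), which is nothing beyond the scatter, although a surprise in either direction remains possible. For compound 3, the estimated value is 9000 nM, with an expected range from 3000 nM to 27000 nM.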

Compound 3, half-maximal inhibitory concentration: 7900 nM
Estimate against measurement, compound 3: 1.1-fold (0.06 log units) above; measured number inside the range.
By their numbers in this assay, from the lowest: compounds 3, 1 and 2 (each within the scatter of the next).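

At the double-bonded chain carbon bound to a double-bonded ring carbon, this assay shows a 1.8-fold lower number from compound 2 to compound 3 (0.26 log units; within the scatter) and also a 1.2-fold lower number from compound 1 to compound 3 (0.08 log units; within the scatter), and both steps lie within the scatter. The earlier step only exchanged 2-bromophenyl for 2,3-dichlorophenyl, whereas 4-hydroxy-3-methoxyphenyl carries oxygen instead of halogen and brings a hydrogen-bond donor and acceptors that the groups it is compared with do not have, yet the three numbers still cannot be ranked. So, in this read-out, even this larger change of atoms at this place produces no step beyond the scatter, and nothing available explains why the numbers stay so close.

The compounds shown do not separate any contribution of the hydroxy group from that of the methoxy group, and every group at this place so far is a substituted phenyl ring. Going by these compounds, whether a ring bearing a carboxylic acid, a ring bearing an amine, or a plain alkyl chain at this place would give a step beyond the scatter remains open.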